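Removing the ethyl group from an amide nitrogen

The compounds below may be only part of what the source reports. "The series", "measured", "known", "first", "only" and "open" are said of these compounds alone.

Of the compounds shown here, two sharing one core have been measured. Compound 1 `Cc1ccccc1-c1c(C(=O)N(C)Cc2ccccc2Cl)n(C)c(=O)c2ccccc12` gives 19 nM in an assay on IM-9 cells for binding affinity to Substance-P receptor (Homo sapiens); on this read-out higher numbers stand for weaker inhibition and lower numbers for stronger inhibition. Compound 2 `CCN(Cc1ccccc1OC)C(=O)c1c(-c2ccccc2C)c2ccccc2c(=O)n1C` gives 34 nM in this assay, the higher of the two numbers, though the gap to compound 1 lies within the scatter. Compound 3 `COc1ccccc1CNC(=O)c1c(-c2ccccc2C)c2ccccc2c(=O)n1C` differs from compound 2 only by hydrogen in place of ethyl on an amide-type nitrogen. Within the data shown here, no measured pair shows this change, so its effect is open. The step from compound 2 to compound 3 is expected to be a modest loss, a 2.9-fold higher number from compound 2 to compound 3 (0.47 log units; beyond the scatter). Compound 3 is therefore estimated at 100 nM, within a range from 30 nM to 400 nM.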

Compound 3, half-maximal inhibitory concentration: 470 nM
Beside the measured number, compound 3's estimate is 4.7-fold (0.67 log units) below it; measured number outside the range, above it.
By their numbers in this assay, from the lowest: compounds 1 and 2 (each within the scatter of the next); then compound 3.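

In this assay, hydrogen in place of ethyl on this amide-type nitrogen gives a 14-fold higher number from compound 2 to compound 3 (1.14 log units; beyond the scatter), so in this pair, the group on the nitrogen has a large effect on the number. The other step, which replaces the whole group on the carbonyl carbon, gives a 25-fold higher number from compound 1 to compound 3 (1.39 log units; beyond the scatter), and it too is large. Nothing measured here explains the loss.

Going by these compounds, whether a longer chain such as propyl, or a cyclopropyl ring, on this nitrogen would match ethyl remains open.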